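Moving from a naphthyl to a hydroxyphenyl sulfonamide

The source may report more compounds than this note shows. Statements on the series, on what has been measured and on what is new or still open speak of the compounds shown alone.

compound 1 `CN(c1ccccc1)S(=O)(=O)C1CC2OC1C(c1ccc(NC(=O)CCCCCCC(=O)O)cc1)=C2c1ccc(O)cc1` gives 63800 nM
compound 2 `CN(c1cccc2ccccc12)S(=O)(=O)C1CC2OC1C(c1ccc(NC(=O)CCCCCCC(=O)O)cc1)=C2c1ccc(O)cc1` gives 14000 nM
compound 3 `CCN(c1ccc(O)cc1)S(=O)(=O)C1CC2OC1C(c1ccc(NC(=O)CCCCCCC(=O)O)cc1)=C2c1ccc(O)cc1` is not yet measured

Among the measured compounds shown here, in a functional assay on MCF7 cells (Homo sapiens) for antiproliferative activity, read by MTT assay, with a stated time of 72 h (on this read-out higher numbers stand for weaker inhibition and lower numbers for stronger inhibition), compound 2 gives 14000 nM, the lowest number so far, while compound 1 stands higher at 63800 nM. The next change is ethyl(4-hydroxyphenyl)amino in place of methyl(naphthalen-1-yl)amino on a sulfonyl sulfur. For the measured compounds named here, one measured step bears on it, with naphthalen-1-yl in place of phenyl on a sulfonamide nitrogen: a 4.6-fold lower number from compound 1 to compound 2 (0.66 log units; beyond the scatter). Compound 3 lacks naphthalen-1-yl, so part of that modest step is expected to reverse, towards a higher number in this assay. The expected change is a 2.1-fold higher number from compound 2 to compound 3 (0.33 log units; beyond the scatter). Compound 3 is estimated at 30000 nM, with an expected range of 10000 nM to 80000 nM.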

Compound 3, half-maximal inhibitory concentration: 46600 nM
Estimate against measurement, compound 3: 1.6-fold (0.19 log units) below; measured number inside the range.
By their numbers in this assay, from the lowest: compound 2; then compounds 3 and 1 (each within the scatter of the next).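

In this assay, ethyl(4-hydroxyphenyl)amino on the sulfonyl sulfur in place of methyl(naphthalen-1-yl)amino gives a 3.3-fold higher number from compound 2 to compound 3 (0.52 log units; beyond the scatter) and thus does not keep the gain seen with naphthalen-1-yl. Set against methyl(phenyl)amino, the same group gives a 1.4-fold lower number from compound 1 to compound 3 (0.14 log units; within the scatter) and leaves compound 1 and compound 3 indistinguishable on this read-out. No measurement shown here explains these steps.

On these data alone, the ethyl and the hydroxyl enter together in compound 3, so their separate contributions stay open. Also open, as far as these compounds go, is how a methoxy group or an amine in place of that hydroxyl would read.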